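The source may hold more compounds than are shown below. What is called first, only, known or untested is meant among the compounds shown, and "the series" means these compounds.

Measured compounds in a functional assay on HaCaT cells (Homo sapiens) for inhibition, read by sulforhodamine B assay, with a stated time of 48 h; a higher number here means a weaker inhibitor of growth, a lower number a stronger inhibitor of growth:
compound 1 `CC1(/C=C/c2cccc(O)c2)C=CC(=O)O1` gives 88100 nM
compound 2 `CC1(/C=C/c2ccc(O)cc2)C=CC(=O)O1` gives 81200 nM
compound 3 `COc1cccc(/C=C/C2(C)C=CC(=O)O2)c1` gives 5700 nM

Compound 1 and compound 2 have the same atoms joined differently; the difference between the two cores is not broken down here. Their values in this assay lie within the scatter of each other, so nothing can be said of an order between them.

Compound 3 differs from compound 1 by methyl in place of hydrogen on an oxygen on an aromatic ring This change gave a 15-fold lower number from compound 1 to compound 3 (1.19 log units; beyond the scatter) in this assay, a step well beyond the scatter.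

Compound 4 `COc1ccc(/C=C/C2(C)C=CC(=O)O2)cc1` is not yet measured. It differs from compound 2 by methyl in place of hydrogen on an oxygen on an aromatic ring The place lines of the two changes read the same word for word, so this is the same change made on the core of compound 2 that was made from compound 1 to compound 3; it occurs twice among the compounds shown, once measured and once not.

Within the data shown here, with only one measured example of the change, the expectation for compound 4 rests on that single step. Among the measured compounds shown here, compound 4 is expected to give a step of a 14-fold lower number from compound 2 to compound 4 (1.13 log units; beyond the scatter) in this assay, of about the same size as the one seen from compound 1 to compound 3, because compound 2 starts from 81200 nM and the change is the same kind. The estimate for compound 4 is 6000 nM, with a range of 2000 nM to 20000 nM; the width reflects that a single prior step is the whole basis.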

Compound 4, concentration for total growth inhibition: 316000 nM
Compound 4: the middle estimate sits 53-fold (1.72 log units) below what was measured; measured number outside the range, above it.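

In this assay, hydroxy to methoxy on the core of compound 2 gave a 3.9-fold higher number from compound 2 to compound 4 (0.59 log units; beyond the scatter), which runs opposite in direction to the step seen on the core of compound 1. In this series the change therefore cannot be carried from one core to another as a fixed step, or even with a fixed direction: the same change on two cores in this assay, a 15-fold lower number (1.19 log units; beyond the scatter) from compound 1 to compound 3 and a 3.9-fold higher number (0.59 log units; beyond the scatter) from compound 2 to compound 4, 60-fold (1.78 log units) apart, beyond the scatter of two such steps. This does not show why the two cores part, nor how the change would behave on any further core, as the comparison rests on a single pair for each core and the two cores hold the same atoms joined differently.

The compounds shown carry only hydrogen or methyl on that oxygen, so it remains open whether a longer chain such as ethyl there, or an amine in place of the whole hydroxy group, would follow the step to compound 3, the step to compound 4, or neither. Going by these compounds, it also remains open whether a carboxylic acid on the aromatic ring would respond differently on the two cores, and whether any such split between the cores extends beyond this one change.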